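A few compounds are considered here, and "the series" means these few. Any claim that something is new, unique, unknown or untested is made for them only; others in the source may bear on it.

Working notes on the series. All four members share one core; compound 1 is `CC(=O)/C(=C/c1c(-c2ccccc2)[nH]c2ccccc12)C(=O)c1ccccc1`, compound 2 is `N#C/C(=C\c1c(-c2ccccc2)[nH]c2ccccc12)C(=O)c1cccs1`, compound 3 is `CCOC(=O)/C(=C/c1c(-c2ccccc2)[nH]c2ccccc12)C(=O)c1ccc([N+](=O)[O-])cc1`, and compound 4, not yet tested, is `CCOC(=O)/C(=C/c1c(-c2ccccc2)[nH]c2ccccc12)C(=O)c1ccccc1`. In a functional assay on SK-MES-1 cells (Homo sapiens) for cytotoxicity, read by MTT assay, with a stated time of 96 h (on this read-out lower numbers stand for an effect already at smaller amounts and higher numbers for an effect only at larger amounts of compound), compound 1 reaches only a limit of the assay, > 100000 nM; a line of the data records that (the limit of > 100000 nM in this assay, at which 1 of the 3 values shown sits). In this assay compound 2 gives 4000 nM, and compound 3 gives 19000 nM, which is the highest of the two numbers on hand, with the gap between compound 2 and compound 3 lying beyond the usual scatter. Compound 4 differs from compound 3 only in hydrogen in place of nitro on an aromatic carbon. Within the data shown here, no measured pair covers this change, so the step can only be expected: compound 4 is estimated to move somewhat toward a higher number, as in a 1.6-fold higher number from compound 3 to compound 4 (0.20 log units; within the scatter), since compound 1, which also carries the plain benzoyl group, gave only > 100000 nM. For compound 4 the expected value is 30000 nM, within a range from 8000 nM to 120000 nM.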

Compound 4, half-maximal effective concentration: > 100000 nM
Compound 4: no number, only a limit; the forecaster's own chance of this, stated with the estimate: 25%; middle value at least 3.3-fold (0.52 log units) away from the limit.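

In this assay, among these compounds, hydrogen in place of nitro on an aromatic carbon, para to a large group, gives an at least 5.2-fold higher number from compound 3 to compound 4 (0.72 log units; beyond the scatter), the first readable step at this position. With the ester held constant, the measurable number of compound 3 therefore depends on the nitro group, and 4-nitrophenyl to phenyl is a change this assay can register. Compound 4 gives only a limit, not a number, and the step from compound 1, ethoxy in place of methyl on a carbonyl carbon, cannot be read from two limits: the limit of > 100000 nM in this assay, at which 2 of the 4 values shown sit.

As far as these compounds go, it remains open whether an amine, a carboxylic acid or chlorine on the same aromatic carbon would also give a number in this assay. Also open, from the compounds shown here alone, is whether methyl in place of ethoxy on the carbonyl carbon would shift the number with the 4-nitrophenyl group kept.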